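Aryl urea series: astrocyte cytotoxicity, moving to compound 4

A few compounds are considered here, and "the series" means these few. Any claim that something is new, unique, unknown or untested is made for them only; others in the source may bear on it.

Measured so far in an ADME assay on cells (Astrocyte, Homo sapiens) for cytotoxicity, read by WST assay, with a stated time of 72 h; on this read-out lower numbers stand for stronger inhibition and higher numbers for weaker inhibition:
- compound 1, `O=C(Nc1ccccc1F)Nc1cc2ncncc2cc1OCc1cccc(Cl)c1`: 8700 nM
- compound 2, `O=C(Nc1ccc(C(F)(F)F)cc1)Nc1cc2ncncc2cc1OCc1cccc(Cl)c1`: 8800 nM
- compound 3, `O=C(Nc1ccc(C(F)(F)F)cc1)Nc1cc2ncncc2cc1OCc1cccc(F)c1`: 8900 nM

Compound 2 stands second highest of the three numbers; its nearest neighbour is compound 3 and its furthest is compound 1, and both gaps are within the scatter. The two measured steps confirm how flat the set is: a 1.0-fold higher number from compound 1 to compound 2 (0.00 log units; within the scatter) and a 1.0-fold higher number from compound 2 to compound 3 (0.00 log units; within the scatter). Neither a change of the aryl group on the urea nitrogen nor an exchange of halogen on the benzyl ether moved the read-out beyond the scatter.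

Compound 4, `O=C(Nc1cccc(Cl)c1)Nc1cc2ncncc2cc1OCc1cccc(Cl)c1`, has not yet been measured. Its difference from compound 2 is 3-chlorophenyl in place of 4-(trifluoromethyl)phenyl on an amide-type nitrogen. The step from compound 1 to compound 2 is the one that bears directly on it, since it also changes the aryl group on that same amide-type nitrogen, and it was flat. On that basis no step beyond the scatter is expected in this assay for compound 4, in either direction.

For compound 4 the expected step is no change at the digits printed from compound 2 to compound 4 (within the scatter), and the estimate is 8800 nM with a range from 4400 nM to 17600 nM.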

Compound 4, half-maximal inhibitory concentration: > 10000 nM
Compound 4: a limit, no number; the forecaster's own chance of this, stated with the estimate: 10%; middle value at least 1.1-fold (0.05 log units) from the limit.
By their numbers in this assay, from the lowest: compounds 1, 2 and 3 (each within the scatter of the next). At a limit, above all of these: compound 4.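

In this assay compound 4 gives > 10000 nM, which is a limit of the assay and not a number. The change of aryl group can therefore be read only as a floor, an at least 1.1-fold higher number from compound 2 to compound 4 (0.05 log units; that floor lies within the scatter) and an at least 1.1-fold higher number from compound 1 to compound 4 (0.06 log units; that floor lies within the scatter), and with both floors within the scatter, 3-chlorophenyl on the amide-type nitrogen is not shown to differ from either 4-(trifluoromethyl)phenyl or 2-fluorophenyl. What this position adds to the earlier compounds is a reading with no upper bound, so the flat picture from compounds 1, 2 and 3 cannot be extended to compound 4 as a measured number: the limit of > 10000 nM in this assay, at which 1 of the 4 values shown sits.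

For the compounds shown here, how far compound 4 lies past the limit remains open, and with it whether the 3-chlorophenyl change is a real step or no step at all. Also open, on these data alone, is whether an aryl group carrying an amine or a carboxylic acid, or a cyclohexyl group in place of the aryl group on the same amide-type nitrogen, would bring the read-out in this assay outside the scatter of compounds 1, 2 and 3.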